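The source may report more compounds than this note shows. Statements on the series, on what has been measured and on what is new or still open speak of the compounds shown alone.

Among the measured compounds shown here, in a functional assay on NCI-H460 cells (Homo sapiens) for cytotoxicity, read by MTT assay, with a stated time of 72 h (a lower number here means a stronger inhibitor, a higher number a weaker inhibitor), compound 3 `O=C(Nc1ccc(-n2ncc3cnccc32)cc1)Nc1ccc(Cl)c(C(F)(F)F)c1` gives 1400 nM, the second highest of the three numbers measured so far; compound 1 `O=C(Nc1ccc(-n2ncc3c(Cl)cccc32)cc1)Nc1ccc(Cl)c(C(F)(F)F)c1` gives 1300 nM and compound 2 `O=C(Nc1ccc(-n2ncc3ccccc32)cc1)Nc1ccc(Cl)c(C(F)(F)F)c1` gives 5500 nM. The step of a 1.1-fold higher number from compound 1 to compound 3 (0.03 log units; within the scatter) lies within the scatter, whereas a 3.9-fold lower number from compound 2 to compound 3 (0.59 log units; beyond the scatter) and a 4.2-fold higher number from compound 1 to compound 2 (0.63 log units; beyond the scatter) are modest steps beyond it. Compound 4 `O=C(Nc1ccc(-n2ncc3ccncc32)cc1)Nc1ccc(Cl)c(C(F)(F)F)c1` differs from compound 3 by a group of 9 heavy atoms (6 carbon, 3 nitrogen; one five-membered aromatic ring with 2 hetero atoms, one six-membered aromatic ring with 1 hetero atom) in place of a group of 9 heavy atoms (6 carbon, 3 nitrogen; one five-membered aromatic ring with 2 hetero atoms, one six-membered aromatic ring with 1 hetero atom), on an aromatic carbon; the two have the same atoms, joined differently. For the measured compounds named here, no measured step moves a ring nitrogen within this bicyclic group, so the only guidance is that exchanging the group as a whole has shifted this assay by a modest step at most. For compound 4 the expected step is a 1.3-fold higher number from compound 3 to compound 4 (0.11 log units; within the scatter). Compound 4 is estimated at 1800 nM, with a range from 600 nM to 6000 nM.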

Compound 4, half-maximal inhibitory concentration: 4800 nM
Compound 4: middle estimate off by 2.7-fold (0.43 log units), on the low side; measured number inside the range.
By their numbers in this assay, from the lowest: compounds 1 and 3 (each within the scatter of the next); then compounds 4 and 2 (each within the scatter of the next).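

In this assay, the place of the ring nitrogen matters, not just its presence: the same atoms joined differently give a 3.4-fold higher number from compound 3 to compound 4 (0.54 log units; beyond the scatter). Adding a ring nitrogen to the group of compound 2 therefore does not always separate the compounds: a 1.1-fold lower number from compound 2 to compound 4 (0.06 log units; within the scatter), while a 3.7-fold higher number from compound 1 to compound 4 (0.57 log units; beyond the scatter) sets compound 4 apart from the chloro compound. Nothing available accounts for the gap between the two isomers.

As far as these compounds go, it remains open whether other placements of the ring nitrogen fall with compound 3 or compound 4. An amine or methoxy group in place of the chloro of compound 1 is also untested in the compounds shown.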